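A few compounds are considered here, and "the series" means these few. Any claim that something is new, unique, unknown or untested is made for them only; others in the source may bear on it.

Going by the values given here, compound 1 `CCC(C#Cc1cccc(C(=O)NCc2ccccc2C(F)(F)F)c1)N(O)C(N)=O` is one of three compounds measured in an assay for inhibition of Polyunsaturated fatty acid 5-lipoxygenase (Homo sapiens), read by HPLC, with stated times of 15 min and 10 min; on this read-out lower numbers stand for stronger inhibition and higher numbers for weaker inhibition. Compound 1 gives 500 nM, the lowest of the three numbers. Compound 3 `COc1ccc(CNC(=O)c2cccc(C#CC(C)N(O)C(N)=O)c2)c(C(F)(F)F)c1` gives 1700 nM, the nearest of the other two, and this gap to compound 1 lies beyond the scatter. Compound 2 `CC(C#Cc1cncc(C(=O)NCc2ccccc2C(F)(F)F)c1)N(O)C(N)=O` gives 10000 nM, the furthest from compound 1, again beyond the scatter.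

Compound 4 `CCCC(C#Cc1cccc(C(=O)NCc2ccccc2C(F)(F)F)c1)N(O)C(N)=O` has not yet been measured in this assay. It differs from compound 1 in one place: methyl in place of hydrogen on a saturated chain carbon, three bonds along the chain from an amide-type nitrogen and a triple-bonded carbon. Among the compounds with values here, no step between two measured compounds shows the effect of this change; the nearest measured difference, between compound 1 and compound 2, concerns the core and the chain together, so it cannot be read as a guide for the chain alone.

On that basis only a small step is expected from compound 1 to compound 4, one that is estimated to lie within the scatter, in either direction, as a 1.1-fold lower number from compound 1 to compound 4 (0.05 log units; within the scatter). Compound 4 is therefore expected to give about 450 nM in this assay, with an estimated range from 150 nM to 1400 nM.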

Compound 4, half-maximal inhibitory concentration: 300 nM
Compound 4: the middle estimate sits 1.5-fold (0.18 log units) above what was measured; low and high end bracket the measured number.
By their numbers in this assay, from the lowest: compounds 4 and 1 (each within the scatter of the next); then compound 3; then compound 2.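

In this assay, going by these compounds alone, the change from ethyl to propyl on this saturated chain carbon gives the only single-place step, a 1.7-fold lower number from compound 1 to compound 4 (0.22 log units; within the scatter). The added methyl therefore leaves the two numbers level within the scatter, so this end of the chain takes one more carbon with no measurable difference on this read-out. No measurement shown here offers an explanation for this result.

The compounds shown leave open whether a longer chain, a branched isopropyl group or a cyclopropyl ring on this carbon would also stay level with compound 1. They also leave open how the propyl chain behaves on other cores, as compound 2 and compound 3 each differ from compound 1 in more than one place.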